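The source may hold more compounds than are shown below. What is called first, only, known or untested is meant among the compounds shown, and "the series" means these compounds.

Working notes on the series.

Compound 1 `Cc1ccsc1/C=C(/SCc1ccc(F)cc1)C(=O)c1ccc(Br)cc1`, compound 2 `COc1ccc(/C=C(/SCc2ccc(F)cc2)C(=O)c2ccc(Br)cc2)cc1O` and compound 3 `O=C(/C(=C\c1ccc(F)cc1C(F)(F)F)S(=O)(=O)Cc1ccc(Cl)c(Cl)c1)c1ccc(Cl)cc1` share one core. In a functional assay on DU-145 cells (Homo sapiens) for inhibition, read by trypan blue exclusion, with a stated time of 96 h (a higher number here means a weaker inhibitor of growth, a lower number a stronger inhibitor of growth), compound 1 gives 50000 nM, compound 2 gives 1000 nM, and compound 3 gives 1000 nM. Compound 2 stands level with compound 3 at the digits shown, the two together the lowest of the three numbers, and far from compound 1, the one measured neighbour that differs from it in a single place: a 50-fold lower number from compound 1 to compound 2 (1.70 log units; beyond the scatter).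

Compound 4 `O=C(/C(=C\c1ccc(O)cc1)SCc1ccc(F)cc1)c1ccc(Br)cc1` is not yet measured in this assay. It differs from compound 2 in one place: 4-hydroxyphenyl in place of 3-hydroxy-4-methoxyphenyl on a double-bonded chain carbon bound to a double-bonded chain carbon. For the measured compounds named here, the only measured step touching the group on the double-bonded chain carbon is the large one from compound 1 to compound 2, and it swapped a whole ring type. Going by the values given here, no measured pair trades one hydroxy-bearing phenyl for another, so nothing here tells how far dropping the methoxy group moves the number. With a phenyl carrying a hydroxy group retained, compound 4 is expected to stay near compound 2, with a step that may not pass beyond the scatter. The expected step is a 2.0-fold higher number from compound 2 to compound 4 (0.30 log units; within the scatter). Compound 4 is therefore estimated at 2000 nM, between 500 nM and 8000 nM.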

Compound 4, concentration for 50% growth inhibition: 10000 nM
For compound 4 the middle estimate is 5.0-fold (0.70 log units) below the measured one; measured number outside the range, above it.
By their numbers in this assay, from the lowest: compounds 2 and 3 (each within the scatter of the next); then compound 4; then compound 1.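

In this assay, the group on the double-bonded chain carbon bound to a double-bonded chain carbon now matters even when the ring type stays the same: with a hydroxy-bearing phenyl kept, the change gives a 10-fold higher number from compound 2 to compound 4 (1.00 log units; beyond the scatter) and lies beyond the scatter, so a hydroxy group on a phenyl ring is not enough to hold the number. The thiophene comparison also gains a second reading, with a 5.0-fold lower number from compound 1 to compound 4 (0.70 log units; beyond the scatter) showing that 4-hydroxyphenyl still improves on 3-methylthiophen-2-yl, though by a smaller step than 3-hydroxy-4-methoxyphenyl does. No supporting data bear on this result, and the size of either step remains unexplained.

The change from 3-hydroxy-4-methoxyphenyl to 4-hydroxyphenyl removes the methoxy group and alters where the hydroxy group stands in a single step, so the compounds shown do not separate these two changes; 3-hydroxyphenyl and 4-methoxyphenyl at this position would be the direct comparisons. Also open, from the compounds shown here alone, is whether the hydroxy group itself is needed, a question that 3-amino-4-methoxyphenyl or an unsubstituted phenyl at the same position would address.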